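Methoxy to hydroxy: a second instance in the series

The compounds below may be only part of what the source reports. "The series", "measured", "known", "first", "only" and "open" are said of these compounds alone.

Compound 1 `COc1cc(-c2nn(-c3cccc(NC(=O)Nc4cc(C(F)(F)F)cc(C(F)(F)F)c4)c3)cc2-c2ccncc2)ccc1Cl` and compound 2 `O=C(Nc1cccc(-n2cc(-c3ccncc3)c(-c3ccc(Cl)c(O)c3)n2)c1)Nc1cc(C(F)(F)F)cc(C(F)(F)F)c1` differ by hydrogen in place of methyl on an oxygen on an aromatic ring. In a functional assay on MCF7 cells (Homo sapiens) for inhibition, read by sulforhodamine B assay, with a stated time of 48 h (on this read-out lower numbers stand for higher toxicity in this test and higher numbers for lower toxicity in this test), compound 1 reaches only a limit, > 50000 nM, at the limit of > 50000 nM in this assay, at which 1 of the 3 values shown sits. In this assay compound 2 gives 31500 nM. The step of an at least 1.5-fold lower number from compound 1 to compound 2 (0.20 log units; that floor lies within the scatter) is therefore bounded by the limit of compound 1.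

Compound 3 `COc1cc(-c2nn(-c3cccc(NC(=O)Nc4ccc(Cl)c(C(F)(F)F)c4)c3)cc2-c2ccncc2)ccc1Cl` gives only a limit in this assay, > 32500 nM, at the limit of > 32500 nM in this assay, at which 1 of the 3 values shown sits. The difference between the core of compound 3 and the core of compound 1 is not broken down here.

Compound 4 `O=C(Nc1cccc(-n2cc(-c3ccncc3)c(-c3ccc(Cl)c(O)c3)n2)c1)Nc1ccc(Cl)c(C(F)(F)F)c1` is obtained from compound 3 by hydrogen in place of methyl on an oxygen on an aromatic ring, the same change as from compound 1 to compound 2, at an identical place. The expected step of an at least 1.0-fold lower number from compound 3 to compound 4 (0.03 log units; that floor lies within the scatter) rests on an at least 1.5-fold lower number from compound 1 to compound 2 (0.20 log units; that floor lies within the scatter), whose floor lies within the scatter. Compound 4 is estimated at 30000 nM, between 10000 nM and 60000 nM.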

Compound 4, concentration lethal to 50% of the cells: > 32500 nM
Compound 4 ended at the assay's limit; the forecaster's own chance of this, stated with the estimate: 40%; at least 1.0-fold (0.03 log units) between middle value and limit.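

No step can be read between compound 3 and compound 4, because both sit at the same limit of the assay: the limit of > 32500 nM in this assay, at which 2 of the 4 values shown sit.

As far as these compounds go, whether methoxy to hydroxy moves the read-out at all stays open, as the step between compound 1 and compound 2 has no second readable instance.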